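Methyl in Place of Chloro on the Core of Compound 1

The source may report more compounds than this note shows. Statements on the series, on what has been measured and on what is new or still open speak of the compounds shown alone.

Compound 1 `CN1CCN(c2ccc3[nH]nc(S(=O)(=O)c4ccc(Cl)cc4)c3c2)CC1`: 8.1 nM
Compound 2 `Cn1nc(S(=O)(=O)c2ccccc2)c2cc(N3CCNCC3)ccc21`: 3.2 nM
Compound 3 `CN1CCN(c2ccc3c(c2)c(S(=O)(=O)c2cccc4ccccc24)nn3Cc2ccccc2)CC1`: 2 nM

In an assay on HeLa cells for displacement of a labelled ligand from 5-hydroxytryptamine receptor 6 (Homo sapiens) (on this read-out lower numbers stand for stronger inhibition and higher numbers for weaker inhibition), compound 1 holds the highest number of the three; compound 2 sits at a lower number, and compound 3 at the lowest of the set. Going by the values given here, none of these pairs differs in a single place, so no measured step guides the move to compound 4 `Cc1ccc(S(=O)(=O)c2n[nH]c3ccc(N4CCN(C)CC4)cc23)cc1`. The change from compound 1 is methyl in place of chloro on an aromatic carbon, a swap that keeps the heavy-atom count and leaves donors, acceptors and charge untouched. For this assay this exchange is expected to give no step beyond the scatter, in either direction. The estimate for compound 4 is 9 nM, between 4 nM and 20 nM, the expected step being a 1.1-fold higher number from compound 1 to compound 4 (0.05 log units; within the scatter).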

Compound 4, inhibition constant: 4.9 nM
For compound 4 the middle estimate is 1.8-fold (0.26 log units) above the measured one; measured number inside the range.
By their numbers in this assay, from the lowest: compounds 3, 2, 4 and 1 (each within the scatter of the next, the first and the last beyond it).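

Going by these compounds alone, this pair is the only comparison in the set that differs in one place: on an aromatic carbon para to a large group, methyl in place of chloro gives a 1.7-fold lower number from compound 1 to compound 4 (0.22 log units; within the scatter) in this assay. At this position, then, the two groups cannot be told apart on this read-out. No measured evidence bears on this result.

Going by these compounds, whether an amine or a carboxylic acid on this carbon would give a step beyond the scatter remains open. Also open, on these data alone, is whether methyl in place of chloro would give a similar step with a substituent on the ring nitrogen.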